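The compounds below may be only part of what the source reports. "The series", "measured", "known", "first", "only" and "open" are said of these compounds alone.

In an ADME assay on microsomes from liver (Homo sapiens) for metabolic stability, read by LC-MS, using NADPH, with stated times of 5 min and 30 min, tested at 1 uM (on this read-out lower numbers stand for slow clearance and higher numbers for fast clearance), compound 3 (`CC(=O)N1CCC(c2cnc(NCc3c(F)ccc4c3CCO4)c3cn[nH]c(=O)c23)CC1`) stands highest of the three measured compounds at 207 mL.min-1.g-1, against compound 1 (`Cn1cc(-c2cnc(NCc3c(F)ccc4c3CCO4)c3cn[nH]c(=O)c23)cn1`) at 21 mL.min-1.g-1 and compound 2 (`Cc1nc(CO)ccc1-c1cnc(NCc2c(F)ccc3c2CCO3)c2cn[nH]c(=O)c12`) at 11 mL.min-1.g-1. The change to compound 4 (`Cc1nc(CN(C)C)ccc1-c1cnc(NCc2c(F)ccc3c2CCO3)c2cn[nH]c(=O)c12`) is 6-((dimethylamino)methyl)-2-methylpyridin-3-yl in place of 1-acetylpiperidin-4-yl on an aromatic carbon. Two measured steps enter 1-acetylpiperidin-4-yl: a 9.9-fold higher number from compound 1 to compound 3 (0.99 log units; beyond the scatter) and a 19-fold higher number from compound 2 to compound 3 (1.27 log units; beyond the scatter). Leaving that group should therefore reverse the trend, and a 1.9-fold lower number from compound 1 to compound 2 (0.28 log units; within the scatter) shows the two other groups sitting close together. Going by the values given here, no measured compound carries a dimethylamino group, which leaves the size uncertain. A clear drop is expected in this assay, an estimated 6.9-fold lower number from compound 3 to compound 4 (0.84 log units; beyond the scatter). Compound 4 is expected at 30 mL.min-1.g-1, with an estimated range of 12 mL.min-1.g-1 to 80 mL.min-1.g-1.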

Compound 4, intrinsic clearance in microsomes: 13 mL.min-1.g-1
The estimate for compound 4 lay 2.3-fold (0.36 log units) above the measured number; measured number inside the range.
By their numbers in this assay, from the lowest: compounds 2, 4 and 1 (each within the scatter of the next); then compound 3.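

In this assay, a 16-fold lower number from compound 3 to compound 4 (1.20 log units; beyond the scatter) shows that 6-((dimethylamino)methyl)-2-methylpyridin-3-yl at this position does not share the fast clearance of 1-acetylpiperidin-4-yl. The side-chain end of the pyridine tolerates a swap: a 1.2-fold higher number from compound 2 to compound 4 (0.07 log units; within the scatter) sets dimethylamino level with hydroxy, and a 1.6-fold lower number from compound 1 to compound 4 (0.21 log units; within the scatter) sets this group level with 1-methyl-1H-pyrazol-4-yl. Nothing on hand gives a cause for these steps.

From the compounds shown here alone, it remains open whether the high number of compound 3 follows the non-aromatic ring or its acetyl, which a piperidine without the acetyl would separate. Also open, going by these compounds, is whether a carboxylic acid or a longer amine chain on that carbon would stay level with dimethylamino and hydroxy.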